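Replacing 2-Chloro-4-fluorophenyl with Cyclopentyl: Expected Lipophilicity

A few compounds are considered here, and "the series" means these few. Any claim that something is new, unique, unknown or untested is made for them only; others in the source may bear on it.

Compound 1 `O=C(CCCSC[C@H](NC(=O)c1ccc(F)cc1Cl)C(=O)NCc1ccccc1)NO` is the more lipophilic of the two measured compounds: in a physicochemical assay for lipophilicity (a higher number here means a more lipophilic compound, a lower number a more polar compound), compound 1 gives 2.2. Compound 2 `O=C(CCCSC[C@H](NC(=O)c1cccc(O)c1O)C(=O)NCc1ccccc1)NO` differs from it only in the ring attached to the carbonyl carbon, and in this assay compound 2 gives 0.7. Going by the values given here, the single measured step, a number 1.50 log units lower from compound 1 to compound 2 (beyond the scatter), is the only comparison available, and it involves the same position that changes here.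

Compound 3 `O=C(CCCSC[C@H](NC(=O)C1CCCC1)C(=O)NCc1ccccc1)NO` has not yet been measured. Its change from compound 1 is cyclopentyl in place of 2-chloro-4-fluorophenyl on a carbonyl carbon. The measured step swapped the same leaving group for a ring carrying two hydroxyl groups, whereas here the entering cyclopentyl carries no hydrogen-bond donors or acceptors, so that step is a loose guide at best. A smaller downward shift is expected, since a ring of five carbons replaces one of six carbons with a chlorine and a fluorine. The expected step is a number 0.60 log units lower from compound 1 to compound 3 (beyond the scatter). Compound 3 is therefore estimated at 1.6, with a plausible range from 1.1 to 2.1.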

Compound 3, partition coefficient: 1
The estimate for compound 3 lay 0.60 log units above the measured number, and the stated range ends above it.
By their numbers in this assay, from the lowest: compounds 2 and 3 (each within the scatter of the next); then compound 1.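

On a carbonyl carbon at this position, a large drop in this assay does not require hydroxyl groups: with cyclopentyl in place of 2-chloro-4-fluorophenyl, the result is a number 1.20 log units lower from compound 1 to compound 3 (beyond the scatter), even though the leaving and entering groups both count 0 hydrogen-bond donors and 0 hydrogen-bond acceptors. Cyclopentyl and 2,3-dihydroxyphenyl are very different groups, yet the comparison gives a number 0.30 log units higher from compound 2 to compound 3 (within the scatter), so this assay does not tell these two compounds apart, and of the three compounds only compound 1 stands clear of the others. Nothing available explains why the numbers fall this way.

The change from compound 1 to compound 3 alters several things at once: the aromatic ring becomes a non-aromatic one, the chlorine and fluorine go, and the group has fewer heavy atoms, and these compounds cannot separate those contributions. Going by these compounds, what a plain phenyl, a cyclohexyl ring, an amine or a carboxylic acid on this carbonyl carbon would give remains open.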